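Three Limits and a Fourth Benzyl Variation

This account rests on a few compounds, and the source may have more. Where it says the series, first, only, none or still open, it means among the compounds named here.

Compound 1 `COc1ccccc1CNc1ncnc2c1ncn2[C@@H]1O[C@H](CO)[C@@H](O)[C@H]1O`, compound 2 `OC[C@H]1O[C@@H](n2cnc3c(NCc4ccc(F)cc4F)ncnc32)[C@H](O)[C@@H]1O` and compound 3 `OC[C@H]1O[C@@H](n2cnc3c(NCc4c(F)ccc(F)c4F)ncnc32)[C@H](O)[C@@H]1O` share one core and differ only in the ring carried on a saturated chain carbon bound to a nitrogen on an aromatic ring. In a functional assay on MCF cells (Homo sapiens) for antiproliferative activity, with a stated time of 72 h (a lower number here means a stronger inhibitor, a higher number a weaker inhibitor), compound 1 reaches only the limit of the assay, > 166000 nM. In this assay compound 2 likewise gives only a limit, > 166000 nM. Compound 3 also stops at a limit in this assay, > 166000 nM. Because all three sit at the limit of > 166000 nM in this assay, at which 3 of the 3 values shown sit, the steps a step that the two limits leave unreadable from compound 1 to compound 2, a step that the two limits leave unreadable from compound 1 to compound 3 and a step that the two limits leave unreadable from compound 2 to compound 3 have no readable size, and no difference beyond the scatter can be seen among these three. Compound 4 `COc1cccc(CNc2ncnc3c2ncn3[C@@H]2O[C@H](CO)[C@@H](O)[C@H]2O)c1O` carries 2-hydroxy-3-methoxyphenyl in place of 2,3,6-trifluorophenyl on a saturated chain carbon bound to a nitrogen on an aromatic ring. For the measured compounds named here, none of the measured steps offers a readable size, so no direction can be drawn from them for this assay. Compound 4 is therefore expected to remain at the limit as well, so that a step that the limit leaves unreadable from compound 3 to compound 4 is expected to be unreadable. The estimate for compound 4 in this assay is 200000 nM, expected between 50000 nM and 800000 nM.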

Compound 4, half-maximal inhibitory concentration: 20200 nM
The estimate for compound 4 lay 9.9-fold (1.00 log units) above the measured number; the measured number lies below the stated range.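

In this assay, the ring on a saturated chain carbon bound to a nitrogen on an aromatic ring now proves able to move the read-out: 2-hydroxy-3-methoxyphenyl gives an at least 8.2-fold lower number from compound 3 to compound 4 (0.91 log units; beyond the scatter), and likewise an at least 8.2-fold lower number from compound 2 to compound 4 (0.91 log units; beyond the scatter) and an at least 8.2-fold lower number from compound 1 to compound 4 (0.91 log units; beyond the scatter). Compound 1, which carries 2-methoxyphenyl, stops at a limit, > 166000 nM, so a methoxy group on this ring is not enough by itself. Compound 4 is the only one of the four that leaves the shared limit: the limit of > 166000 nM in this assay, at which 3 of the 4 values shown sit.

Going by these compounds, the steps among compound 1, compound 2 and compound 3 still cannot be read, and the true size of each new step remains open. Also open, on these data alone, is whether the hydroxyl group carries the change, something a plain 2-hydroxyphenyl ring, or an amine in the hydroxyl's place, could help to separate.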